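Series notes: carbonyl substituent step toward compound 3

The compounds below may be only part of what the source reports. "The series", "measured", "known", "first", "only" and "open" are said of these compounds alone.

Compound 1 `Cc1ccc(S(=O)(=O)Oc2ccc(/C=N/NC(=O)Cc3ccccn3)cc2)cc1` and compound 2 `Cc1ccc(S(=O)(=O)Oc2ccc(/C=N/NC(=O)c3nc4ccccc4[nH]3)cc2)cc1` share one core and differ only at the carbonyl carbon. In an assay for inhibition of Alpha amylase (Homo sapiens) (on this read-out higher numbers stand for weaker inhibition and lower numbers for stronger inhibition), compound 1 gives > 200000 nM, a limit of the assay. In this assay compound 2 gives > 200000 nM, likewise a limit. The step that the two limits leave unreadable from compound 1 to compound 2 cannot be read, since both values sit at the limit of > 200000 nM in this assay, at which 2 of the 2 values shown sit. Compound 3 `Cc1ccc(S(=O)(=O)Oc2ccc(/C=N/NC(=O)c3ccc(O)cc3)cc2)cc1` carries 4-hydroxyphenyl in place of 1H-benzimidazol-2-yl on a carbonyl carbon. No readable step bears on this change. Compound 3 is expected to stay near the limit, with an estimate of 300000 nM, ranging from 100000 nM to 1000000 nM. The step that the limit leaves unreadable from compound 2 to compound 3 is expected to lie within the scatter.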

Compound 3, half-maximal inhibitory concentration: > 200000 nM
Compound 3: no number, only a limit (the forecaster's own chance of this, stated with the estimate: 75%); the middle value does not contradict the limit.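

Among these compounds, no step among compound 1, compound 2 and compound 3 can be read in this assay, since all three values are limits: the limit of > 200000 nM in this assay, at which 3 of the 3 values shown sit.

The compounds shown leave open whether any carbonyl substituent on the shared core gives a readable value in this assay.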